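The source may report more compounds than this note shows. Statements on the series, on what has been measured and on what is new or still open speak of the compounds shown alone.

Measured in a functional assay on blood for inhibition of Polyunsaturated fatty acid 5-lipoxygenase (Homo sapiens); a higher number here means a weaker inhibitor, a lower number a stronger inhibitor:
compound 1 `COC1(c2cc(Sc3ccc4c(c3)CCC(=O)N4C)cc(F)c2C)CCOCC1` gives 60 nM;
compound 2 `CC(=O)N(C)c1ccc(Sc2ncc([C@]3(C)COC(C)(C)O3)s2)cc1` gives 6210 nM;
compound 3 `CC(=O)N(C)c1ccc(Sc2ncc([C@@]3(C)COC(C)(C)O3)s2)cc1` gives 70 nM.

Compound 3 stands second highest of the three numbers, within the scatter of compound 1 and far from compound 2. Within the data shown here, the only measured step is an 89-fold lower number from compound 2 to compound 3 (1.95 log units; beyond the scatter), which rests on configuration alone because of the fact that compounds 2 and 3 differ only in the configuration as drawn. Compound 4 `C/C(=N\OCC#N)c1ccc(Sc2ncc([C@@]3(C)COC(C)(C)O3)s2)cc1` differs from compound 3 by a group of 7 heavy atoms (4 carbon, 2 nitrogen, 1 oxygen; no ring) in place of a group of 5 heavy atoms (3 carbon, 1 nitrogen, 1 oxygen; no ring), on an aromatic carbon. Among the measured compounds shown here, no measured step alters this position, so the data give no direct guide to the size of the step in this assay, and no change beyond the scatter is expected. The step of a 1.4-fold higher number from compound 3 to compound 4 (0.15 log units; within the scatter) is therefore expected to stay within the scatter. Compound 4 is estimated to give 100 nM in this assay, with a range from 30 nM to 400 nM.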

Compound 4, half-maximal inhibitory concentration: 30 nM
Beside the measured number, compound 4's estimate is 3.3-fold (0.52 log units) above it, within the range that was stated.
By their numbers in this assay, from the lowest: compounds 4, 1 and 3 (each within the scatter of the next, the first and the last beyond it); then compound 2.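

Replacing the acetyl(methyl)amino group, para to a large group, with a chain of 7 heavy atoms ending in a triple bond gives, in this assay, a 2.3-fold lower number from compound 3 to compound 4 (0.37 log units; beyond the scatter). Among these compounds, this is the first measured change at this position, and it shows that the acetyl(methyl)amino group is not needed there to keep the number low on this core. Nothing measured here explains the step.

From the compounds shown here alone, it remains open whether the nitrile itself matters or the chain as a whole. Equally open, going by these compounds, is what a simple amine or a carboxylic acid at this position would give.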